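The source may report more compounds than this note shows. Statements on the series, on what has been measured and on what is new or still open speak of the compounds shown alone.

Working notes on a small set of biphenyl carboxylic acids bearing an imidazole, all read in an in vitro functional assay on cells for agonist activity at Bombesin receptor subtype-3 (Homo sapiens), read by luminescence and calcium flux; on this read-out higher numbers stand for an effect only at larger amounts of compound and lower numbers for an effect already at smaller amounts.

Compound 1 `O=C(O)c1ccccc1-c1ccc(CCc2ncc(CC3CCCCC3)[nH]2)cc1` carries a cyclohexylmethyl group on the imidazole and a two-carbon linker to the biphenyl; in this assay compound 1 gives 41 nM. Compound 2 `CCCCc1cnc(C(C)Cc2ccc(-c3ccccc3C(=O)O)cc2)[nH]1` has a butyl on the imidazole and a branched linker; in this assay compound 2 gives 2760 nM. Compound 3 `CCCCc1cnc(CCCc2ccc(-c3ccccc3C(=O)O)cc2)[nH]1` keeps the butyl and has a three-carbon linker; in this assay compound 3 gives 5600 nM. Among the measured compounds shown here, compound 2 and compound 3 differ from compound 1 in more than one place, so no single-change step can be drawn from them. On the numbers shown, compound 1 stands lowest of the three, with the gaps to compound 2 and to compound 3 both well beyond the scatter, while compound 2 and compound 3 sit close to each other.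

The next compound, compound 4 `O=C(O)c1ccccc1-c1ccc(CCc2ncc(CC3CCOCC3)[nH]2)cc1`, differs from compound 1 in one place: oxan-4-yl in place of cyclohexyl on a saturated chain carbon bound to an aromatic carbon. For the measured compounds named here, no measured pair in the set isolates this change, so the expectation rests on compound 1 alone. A modest rise in this assay is expected, within or a little beyond the scatter, giving an estimated step of a 2.9-fold higher number from compound 1 to compound 4 (0.47 log units; beyond the scatter). Compound 4 is therefore expected at about 120 nM, in a range from 35 nM to 400 nM.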

Compound 4, half-maximal effective concentration: 338 nM
For compound 4 the middle estimate is 2.8-fold (0.45 log units) below the measured one; the range from low to high includes it.
By their numbers in this assay, from the lowest: compound 1; then compound 4; then compound 2; then compound 3.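

In this assay, replacing cyclohexyl with oxan-4-yl on a saturated chain carbon bound to an aromatic carbon gives an 8.2-fold higher number from compound 1 to compound 4 (0.92 log units; beyond the scatter). Among the compounds shown here, this is the first single-change step, and it shows that this position responds to a swap that leaves the six-membered ring and the count of 6 heavy atoms intact, while one ring carbon becomes oxygen and the hydrogen-bond acceptor count goes from 0 to 1. No measurement on hand bears on why the number rises, so the step stands as an observation only.

A single pair cannot separate the effect of the ring oxygen from that of removing a ring carbon, and a piperidin-4-yl group, with a ring amine in the same place, or a phenyl ring in place of the cyclohexyl would help to define what this position accepts. From the compounds shown here alone, it also remains open whether the same change gives a step of similar size when the two-carbon linker of compound 1 is replaced by the branched linker or the three-carbon linker.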